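The source may report more compounds than this note shows. Statements on the series, on what has been measured and on what is new or still open speak of the compounds shown alone.

Compound 1, `CC(C)CN(c1ccc(N(C)C)cc1)S(=O)(=O)c1ccc2c(c1)C(O)CC(C1CCOCC1)O2`, in a physicochemical assay for lipophilicity, at pH 7.4; on this read-out higher numbers stand for higher lipophilicity and lower numbers for lower lipophilicity: 3.51
Compound 2, `CCc1ccc(N(CC(C)C)S(=O)(=O)c2ccc3c(c2)C(C)CC(C2CCOCC2)O3)cc1`, in this assay: 5.71
Compound 3, `CCc1ccc(N(CC(C)C)S(=O)(=O)c2ccc3c(c2)C(O)CC(C2CCOCC2)O3)cc1`, in this assay: 4.12

Among these three numbers compound 3 stands second highest; its nearest neighbour is compound 1, lower by a number 0.61 log units higher from compound 1 to compound 3 (beyond the scatter), and its furthest is compound 2, higher by a number 1.59 log units lower from compound 2 to compound 3 (beyond the scatter). Both steps are beyond the scatter, the second one large.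

Compound 4, `CC(C)CN(C1CCc2ccc(F)cc21)S(=O)(=O)c1ccc2c(c1)C(O)CC(C1CCOCC1)O2`, is not yet measured in this assay. It differs from compound 3 in one place: 6-fluoro-2,3-dihydro-1H-inden-1-yl in place of 4-ethylphenyl on a sulfonamide nitrogen. Neither measured step touches the sulfonamide nitrogen: the step from compound 1 to compound 3 changes a group on an aromatic carbon, and the step from compound 2 to compound 3 changes a group on a saturated ring carbon. They therefore give no direct guide to the size of this change. The entering group carries 10 heavy atoms where the leaving group carried 8, so compound 4 is expected to sit a small step higher than compound 3, a number 0.28 log units higher from compound 3 to compound 4 (within the scatter), with the outcome quite possibly within the scatter. The estimate for compound 4 in this assay is 4.4, within 3.9 to 4.9.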

Compound 4, distribution coefficient: 3.94
The estimate for compound 4 lay 0.46 log units above the measured number; the measured number falls inside the stated range.
By their numbers in this assay, from the lowest: compound 1; then compounds 4 and 3 (each within the scatter of the next); then compound 2.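

On the sulfonamide nitrogen, in this assay, 6-fluoro-2,3-dihydro-1H-inden-1-yl in place of 4-ethylphenyl gives a number 0.18 log units lower from compound 3 to compound 4 (within the scatter), so this exchange, although it brings more heavy atoms, a fluorine and a five-membered non-aromatic ring, does not separate the two compounds. At the same position, 6-fluoro-2,3-dihydro-1H-inden-1-yl in place of 4-(dimethylamino)phenyl gives a number 0.43 log units higher from compound 1 to compound 4 (beyond the scatter), a modest step that can be told from the scatter. Nothing measured here offers an explanation for either step.

Going by these compounds, the fluorine and the five-membered ring enter together, so what each contributes alone remains open, as it would with the unsubstituted 2,3-dihydro-1H-inden-1-yl group. Also open, on these data alone, is how the read-out would respond at this nitrogen to a group carrying a carboxylic acid or a saturated ring such as cyclohexyl.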